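A few compounds are considered here, and "the series" means these few. Any claim that something is new, unique, unknown or untested is made for them only; others in the source may bear on it.

Compound 1 `CC(O)(CSc1cccc(S(F)(F)(F)(F)F)c1)C(=O)Nc1cccc(S(F)(F)(F)(F)F)c1`: 30300 nM
Compound 2 `CC(O)(CSc1cccc(C(F)(F)F)c1)C(=O)Nc1cccc(S(F)(F)(F)(F)F)c1`: 19100 nM

In a functional assay on DU-145 cells (Homo sapiens) for antiproliferative activity, read by propidium iodide staining, with a stated time of 96 h (a higher number here means a weaker inhibitor, a lower number a stronger inhibitor), compound 2 gives 19100 nM, which lies within the scatter of compound 1 at 30300 nM. Both numbers sit in the same high range, and neither compound can be ranked over the other.

Compound 3 `CC(O)(CSc1cccc(OC(F)(F)F)c1)C(=O)Nc1cccc(S(F)(F)(F)(F)F)c1` keeps the core of compound 2 and carries trifluoromethoxy in place of trifluoromethyl on an aromatic carbon. Among the measured compounds shown here, only one measured step bears on this change: a 1.6-fold lower number from compound 1 to compound 2 (0.20 log units; within the scatter). It also exchanges one group for another on an aromatic carbon, and it stays within the scatter. That is a single step, so it offers thin support, but it gives no reason to expect a shift beyond the scatter in this assay, in either direction. The expected step is a 1.1-fold higher number from compound 2 to compound 3 (0.04 log units; within the scatter), which is no real change. For compound 3 the estimate is 21000 nM, with an expected range of 10000 nM to 42000 nM.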

Compound 3, half-maximal inhibitory concentration: 25000 nM
Estimate against measurement, compound 3: 1.2-fold (0.08 log units) below; the range from low to high includes it.
By their numbers in this assay, from the lowest: compounds 2, 3 and 1 (each within the scatter of the next).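

In this assay, trifluoromethoxy in place of trifluoromethyl, on an aromatic carbon and meta to a large group, gives a 1.3-fold higher number from compound 2 to compound 3 (0.12 log units; within the scatter) and so adds a hydrogen-bond acceptor to the group without a shift that can be told from the scatter. The comparison with the larger group of compound 1 gives a 1.2-fold lower number from compound 1 to compound 3 (0.08 log units; within the scatter) and likewise stays within the scatter. Among the compounds shown here, three different groups at this place now fail to separate in this assay, a wider finding than the single earlier step could offer, though no independent data accompany these numbers to account for it.

The compounds shown leave open whether an amine, a carboxylic acid or a longer chain at this place would move the number beyond the scatter. They also leave open whether a change elsewhere on the shared core would do so.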